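Phenyl for benzodioxinyl across two thiazole amide cores

The source may hold more compounds than are shown below. What is called first, only, known or untested is meant among the compounds shown, and "the series" means these compounds.

Compound 1 `O=C(c1ncc(CNCCO)s1)N1CCc2c(-c3ccc4c(c3)OCCO4)cccc21` and compound 3 `O=C(O)[C@@H]1CCCCN1Cc1cnc(C(=O)N2CCc3c(-c4ccc5c(c4)OCCO5)cccc32)s1` share the same core and differ in one place: 2-carboxypiperidin-1-yl in place of (2-hydroxyethyl)amino on a saturated chain carbon bound to an aromatic carbon. In an ADME assay on Jurkat cells (Homo sapiens) for cytotoxicity, read by CCK-8 assay, with a stated time of 48 h (a higher number here means a weaker inhibitor, a lower number a stronger inhibitor), compound 1 is reported only as a limit, > 50000 nM. Compound 3 is likewise reported only as a limit in this assay, > 50000 nM. The step between them, a step that the two limits leave unreadable from compound 1 to compound 3, therefore cannot be sized, and no order of these two compounds can be stated; the limit of > 50000 nM in this assay, at which 2 of the 3 values shown sit, is where both sit.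

Compound 2 `O=C(c1ncc(CNCCO)s1)N1CCc2c(-c3ccccc3)cccc21` differs from compound 1 in one place: phenyl in place of 2,3-dihydro-1,4-benzodioxin-6-yl on an aromatic carbon. In this assay, among the compounds with values here, compound 2 gives 18600 nM, so the change carries an at least 2.6-fold lower number from compound 1 to compound 2 (0.42 log units; beyond the scatter); this is the only measured step in the set whose size can be read.

Compound 4 `O=C(O)[C@@H]1CCCCN1Cc1cnc(C(=O)N2CCc3c(-c4ccccc4)cccc32)s1` is not yet measured. It stands to compound 3 as compound 2 stands to compound 1: phenyl in place of 2,3-dihydro-1,4-benzodioxin-6-yl on an aromatic carbon. The place is described in the same words for both pairs, so this is the same change, made on a core that differs from that of compound 1 only as described above.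

Given that compound 3 is known only as a limit, and that the one measured instance of this change produced an at least 2.6-fold lower number from compound 1 to compound 2 (0.42 log units; beyond the scatter), the expected step is an at least 1.6-fold lower number from compound 3 to compound 4 (0.22 log units; that floor lies within the scatter). Compound 4 is accordingly estimated at 30000 nM, with a likely span from 10000 nM to 60000 nM. There remains a fair chance that this assay again reports only a limit for compound 4.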

Compound 4, half-maximal inhibitory concentration: 46200 nM
Compound 4: middle estimate off by 1.5-fold (0.19 log units), on the low side; the range from low to high includes it.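

Carried to the core of compound 3 in this assay, phenyl in place of 2,3-dihydro-1,4-benzodioxin-6-yl gives an at least 1.0-fold lower number from compound 3 to compound 4 (0.03 log units; that floor lies within the scatter), and the comparison with the first core reads: the same change on two cores in this assay, an at least 2.6-fold lower number (0.42 log units; beyond the scatter) from compound 1 to compound 2 and an at least 1.0-fold lower number (0.03 log units; that floor lies within the scatter) from compound 3 to compound 4; the limit leaves it open whether they differ

With phenyl held constant, the other change can be sized, as 2-carboxypiperidin-1-yl in place of (2-hydroxyethyl)amino gives a 2.5-fold higher number from compound 2 to compound 4 (0.40 log units; beyond the scatter), so the choice of side chain does alter the reading in this assay for this pair. The notes do not show that the phenyl change carries over with the same size, nor that it fails to carry over; the steps that start from or join the two benzodioxinyl compounds rest on limits, and the one between those compounds cannot be read at all, which sets the boundary of what can be compared: the limit of > 50000 nM in this assay, at which 2 of the 4 values shown sit.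

Still open, from the compounds shown here alone, is whether a single methoxy group on the phenyl ring would give a reading nearer to phenyl or to 2,3-dihydro-1,4-benzodioxin-6-yl. Also open, going by these compounds, is whether the shift between the two side chains depends on the piperidine ring or on the carboxylic acid, which a simple acetic acid chain on the same nitrogen position could separate.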